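Furan isomer swap on the shared core: compound 3 to 4

This account rests on a few compounds, and the source may have more. Where it says the series, first, only, none or still open, it means among the compounds named here.

The series shares the core of compound 1 `C=Cc1ccc(-c2cc(C)c3ncc(CSCCc4ccccc4)n3c2)cc1` and varies the group on the aromatic carbon. In an ADME assay on HEL cells (Homo sapiens) for cytotoxicity, with a stated time of 3 days (on this read-out higher numbers stand for lower toxicity in this test and lower numbers for higher toxicity in this test), compound 1 gives 20 ug/mL, and compound 2 `Cc1cc(-c2ccc(C=O)cc2)cn2c(CSCCc3ccccc3)cnc12` gives 100 ug/mL, a move of a 5.0-fold higher number from compound 1 to compound 2 (0.70 log units; beyond the scatter). Compound 3 `Cc1cc(-c2ccco2)cn2c(CSCCc3ccccc3)cnc12` gives only a limit in this assay, > 4 ug/mL. Because of the limit of > 4 ug/mL in this assay, at which 1 of the 3 values shown sits, the steps a step that the limit leaves unreadable from compound 1 to compound 3 and a step that the limit leaves unreadable from compound 2 to compound 3 stay unreadable, so compound 3 stands apart from the two numbers rather than in order with them. Compound 4 `Cc1cc(-c2ccoc2)cn2c(CSCCc3ccccc3)cnc12` differs by furan-3-yl in place of furan-2-yl on an aromatic carbon. Going by the values given here, no measured step bears on this rearrangement, so no change beyond the scatter is expected in this assay, and compound 3 itself gives only a limit. Compound 4 is estimated at 20 ug/mL, within 4 ug/mL to 100 ug/mL, meaning an expected step that the limit leaves unreadable from compound 3 to compound 4.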

Compound 4, minimum cytotoxic concentration: > 4 ug/mL
Compound 4 was reported as a limit; the forecaster's own chance of this, stated with the estimate: 60%; the middle value lies beyond the limit too.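

In this assay compound 4 gives only a limit, > 4 ug/mL. The steps to compound 4 from compound 1, compound 2 and compound 3 therefore cannot be read, and the reason is this: the limit of > 4 ug/mL in this assay, at which 2 of the 4 values shown sit.

On these data alone, whether furan-3-yl and furan-2-yl differ in this assay, and where compound 3 and compound 4 stand relative to compound 1 and compound 2, stays open.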